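Mesylation of the hydroxypiperidine thiocarbamate in the cytotoxicity series

A few compounds are considered here, and "the series" means these few. Any claim that something is new, unique, unknown or untested is made for them only; others in the source may bear on it.

Measured so far in an ADME assay on HeLa cells (Homo sapiens) for cytotoxicity; a higher number here means a weaker inhibitor, a lower number a stronger inhibitor:
compound 1 `Cc1ncc([N+](=O)[O-])n1CCSC(=S)N1CCC(=O)CC1`, compound 1 gives > 1000 ug/mL
compound 2 `Cc1ncc([N+](=O)[O-])n1CCSC(=S)N1CCC(O)CC1`, compound 2 gives 930 ug/mL
compound 3 `Cc1ncc([N+](=O)[O-])n1CCSC(=S)N1C(C)CCCC1C`, compound 3 gives 130 ug/mL

The value of compound 1 is a limit of the assay, not a number (the limit of > 1000 ug/mL in this assay, at which 1 of the 3 values shown sits). Among the two numbers, compound 2 stands highest; compound 3 sits a good way lower. For the measured compounds named here, the one measured step that touches the same position, an at least 1.0-fold lower number from compound 1 to compound 2 (0.03 log units; that floor lies within the scatter), 4-hydroxypiperidin-1-yl in place of 4-oxopiperidin-1-yl on a thiocarbonyl carbon, lies within the scatter.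

Compound 4 `Cc1ncc([N+](=O)[O-])n1CCSC(=S)N1CCC(OS(C)(=O)=O)CC1` differs from compound 2 by methylsulfonyl in place of hydrogen on an oxygen on a saturated carbon. Going by the values given here, no measured step covers a methylsulfonyl entering at this oxygen; the only neighbouring change, from compound 1 to compound 2, moved the number within the scatter. On that basis the expected step in this assay is small, a 1.3-fold lower number from compound 2 to compound 4 (0.12 log units; within the scatter), with a modest chance that the number again runs into the limit of the assay. Compound 4 is therefore expected to give about 700 ug/mL, in the range 300 ug/mL to 1000 ug/mL.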

Compound 4, half-maximal inhibitory concentration: > 1000 ug/mL
Compound 4 gave a limit, no number (the forecaster's own chance of this, stated with the estimate: 25%); middle value at least 1.4-fold (0.15 log units) away from the limit.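

In this assay compound 4 gives > 1000 ug/mL, which is a limit of the assay and not a number. Methylsulfonyl in place of hydrogen on this oxygen reads only as a floor, an at least 1.0-fold higher number from compound 2 to compound 4 (0.03 log units; that floor lies within the scatter), so the change shows no sign of a lower number at this position, while the true size of the step stays unknown. With the hydroxy capped as (methylsulfonyl)oxy, this position has now reached the limit twice, once with the 4-oxopiperidin-1-yl group and once with this ester, and the series now stands as follows: the limit of > 1000 ug/mL in this assay, at which 2 of the 4 values shown sit.

From the compounds shown here alone, whether any replacement of the hydroxy gives a readable number that clearly departs from compound 2 remains open. An amine or a carboxylic acid on this saturated ring carbon, or a longer chain on the sulfonyl group, would test that.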